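The source may hold more compounds than are shown below. What is called first, only, known or untested is meant among the compounds shown, and "the series" means these compounds.

Working notes on the benzoxazole bis-sulfonamide series.

Compound 1 `COc1ccc(S(=O)(=O)Nc2ccc3oc(-c4ccc(NS(=O)(=O)c5cc(F)ccc5OC)cc4)nc3c2)cc1` is the reference point. In a functional assay on HCT-116 cells (Homo sapiens) for cytotoxicity, read by resazurin assay, with a stated time of 48 h (a lower number here means that less compound is needed, a higher number that more compound is needed for the effect), compound 1 gives 15000 nM. Two further members of the set have been measured: compound 2 `COc1ccccc1S(=O)(=O)Nc1ccc(-c2nc3cc(NS(=O)(=O)c4ccccc4OC)ccc3o2)cc1`, which in this assay gives 9200 nM, and compound 3 `O=S(=O)(Nc1ccc(-c2nc3cc(NS(=O)(=O)c4ccc(Br)cc4)ccc3o2)cc1)c1ccc(Br)cc1`, which in this assay gives 11000 nM. The three values sit within the usual scatter of one another, so no ranking among compound 1, compound 2 and compound 3 can be read from them; the set so far describes a single, weak level of cytotoxicity with no resolved structure–activity step.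

Compound 4 `COc1ccc(S(=O)(=O)Nc2ccc3oc(-c4ccc(NC(=O)c5cccc(C)c5[N+](=O)[O-])cc4)nc3c2)cc1` is the next member to be examined. It differs from compound 1 as follows: a group of 12 heavy atoms (8 carbon, 1 nitrogen, 3 oxygen; one six-membered aromatic ring of carbon only) in place of a group of 12 heavy atoms (7 carbon, 3 oxygen, 1 fluorine, 1 sulfur; one six-membered aromatic ring of carbon only), on a nitrogen on an aromatic ring. This exchanges one of the two sulfonamide arms of compound 1 for a (3-methyl-2-nitrophenyl)carbonyl arm while the rest of the molecule is kept.

Among the measured compounds shown here, no measured pair in the set shows what such an exchange does, so the expectation rests on compound 1 alone. The step from compound 1 to compound 4 in this assay is expected to be a 1.2-fold lower number from compound 1 to compound 4 (0.06 log units; within the scatter), that is, no change beyond the scatter in either direction. Compound 4 is therefore estimated to give 13000 nM in this assay, with a range from 4000 nM to 45000 nM.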

Compound 4, half-maximal effective concentration: 4400 nM
Beside the measured number, compound 4's estimate is 3.0-fold (0.47 log units) above it; the measured number falls inside the stated range.
By their numbers in this assay, from the lowest: compound 4; then compounds 2, 3 and 1 (each within the scatter of the next).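

In this assay, among the compounds shown here, replacing one sulfonamide arm with (3-methyl-2-nitrophenyl)carbonyl, on a nitrogen on an aromatic ring, gives a 3.4-fold lower number from compound 1 to compound 4 (0.53 log units; beyond the scatter), the first step beyond the scatter. This position therefore responds to the identity of the arm, even though the leaving and entering groups match in heavy-atom, hydrogen-bond donor and hydrogen-bond acceptor counts, so those counts alone do not fix the cytotoxicity level in this pair. Nothing available bears on the reason for the step, which stands as an observation from a single pair.

The exchange alters the linking carbonyl and the ring substituents together, so the compounds shown do not separate the contribution of the carbonyl link from that of the methyl and nitro groups. As far as these compounds go, an unsubstituted benzoyl arm would isolate the carbonyl link and an amine in place of the nitro group would probe that substituent, while the effect of the same exchange on the other sulfonamide arm remains open.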